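A few compounds are considered here, and "the series" means these few. Any claim that something is new, unique, unknown or untested is made for them only; others in the source may bear on it.

Measured compounds:
compound 1 `Nc1ccc2cccc(OCCC(F)(F)F)c2n1`, which in an assay on cells with melanin-concentrating hormone receptor 1 (Homo sapiens) as the target, read by radioligand binding (a lower number here means a stronger inhibitor, a higher number a weaker inhibitor), gives 722 nM
compound 2 `CC1CC1COc1cccc2ccc(N)nc12`, which in this assay gives 1640 nM

Compound 2 stands with the highest of the two numbers in this assay; its nearest neighbour is compound 1, and the step of a 2.3-fold higher number from compound 1 to compound 2 (0.36 log units; beyond the scatter) separates them. Compound 3 `CCCCCOc1cccc2ccc(N)nc12` is the next compound, and it differs from compound 2 by butyl in place of 2-methylcyclopropyl on a saturated chain carbon bound to an oxygen on an aromatic ring. Among the measured compounds shown here, only one measured step touches the same place: a 2.3-fold higher number from compound 1 to compound 2 (0.36 log units; beyond the scatter) exchanged one group at the saturated chain carbon bound to the oxygen for another, and that exchange moved the number by a modest amount. For the measured compounds named here, no measured step shows a ring of this kind opened into a chain, so the direction is uncertain. The account therefore expects a step of about a 1.4-fold lower number from compound 2 to compound 3 (0.14 log units; within the scatter), close to the scatter, and estimates compound 3 at 1200 nM in this assay, with a range from 400 nM to 3600 nM.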

Compound 3, half-maximal inhibitory concentration: 580 nM
For compound 3 the middle estimate is 2.1-fold (0.32 log units) above the measured one, within the range that was stated.
By their numbers in this assay, from the lowest: compounds 3 and 1 (each within the scatter of the next); then compound 2.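

In this assay, butyl in place of 2-methylcyclopropyl gives a 2.8-fold lower number from compound 2 to compound 3 (0.45 log units; beyond the scatter), so at this place a group with no ring and one with a three-membered ring, each of 4 heavy atoms, are not interchangeable. Propyl in place of trifluoromethyl, on a saturated chain carbon two bonds along the chain from an oxygen on an aromatic ring, gives a 1.2-fold lower number from compound 1 to compound 3 (0.10 log units; within the scatter), so these numbers do not tell those two chain ends apart. Nothing measured here bears on the reason for either step. As far as these compounds go, whether a longer chain such as hexyl would keep the number of compound 3 remains open. So does how an amine or a hydroxyl at the end of the chain would fare, and whether a cyclopropyl group lacking the methyl would track compound 2.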